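Next step in the series: compound 3

The source may report more compounds than this note shows. Statements on the series, on what has been measured and on what is new or still open speak of the compounds shown alone.

Compound 2 `CCc1ccc(S(=O)(=O)NC(=O)Nc2ccc(Cl)cc2)s1` stands level with compound 1 `O=C(Nc1ccc(Cl)cc1)NS(=O)(=O)c1ccc(Cl)s1` at the digits shown: in a functional assay on the whole organism (6C3HED cells, Mus musculus) for inhibition, at a dose of 300 mg/kg by the oral route (a lower number here means less inhibition, a higher number more inhibition at the dose given (going by the name of the read-out)), compound 1 gives 89% and compound 2 gives 89%, the step of no change at the digits printed from compound 1 to compound 2 (within the scatter) falling within the scatter. Compound 3 `CCc1ccc(S(=O)(=O)NC(=O)Nc2ccc(Cl)cc2)o1` differs from compound 2 by 5-ethylfuran-2-yl in place of 5-ethylthiophen-2-yl on a sulfonyl sulfur. Within the data shown here, no measured step bears directly on this change; the single step measured, no change at the digits printed from compound 1 to compound 2 (within the scatter), alters a different part of the molecule, so no direction can be read from it. Compound 3 is therefore expected to change little, a number 4 percentage points lower from compound 2 to compound 3 (within the scatter), and is estimated in this assay at 85% with a range from 70% to 95%.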

Compound 3, a percentage reported as inhibition, in the whole organism at one dose (the size of the read-out at that dose, not a potency): 80%
Beside the measured number, compound 3's estimate is 5 percentage points above it; measured number inside the range.
By their numbers in this assay, from the lowest: compounds 3, 1 and 2 (each within the scatter of the next).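

In this assay the ring on the sulfonyl sulfur can itself be exchanged, not only its substituent: 5-ethylfuran-2-yl in place of 5-ethylthiophen-2-yl gives a number 9 percentage points lower from compound 2 to compound 3 (within the scatter) as the step. Changing ring and substituent together, 5-ethylfuran-2-yl in place of 5-chlorothiophen-2-yl, gives a number 9 percentage points lower from compound 1 to compound 3 (within the scatter) and so separates the compounds no further. No data on hand account for these read-outs.

Open, as far as these compounds go, is whether this level holds with a carboxylic acid or a longer chain such as butyl in place of the ethyl of 5-ethylfuran-2-yl.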